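The source may report more compounds than this note shows. Statements on the series, on what has been measured and on what is new or still open speak of the compounds shown alone.

Measured so far in a functional assay on HeLa cells (Homo sapiens) for antiproliferative activity, read by MTT assay, with a stated time of 72 h; on this read-out lower numbers stand for stronger inhibition and higher numbers for weaker inhibition:
- compound 1 `Cc1ccc(N2CCN(C(=S)SCc3ccc4nc(N)nc(N)c4c3)CC2)cc1`: 2130 nM
- compound 2 `CC(=O)c1ccc(N2CCN(C(=S)SCc3ccc4nc(N)nc(N)c4c3)CC2)cc1`: 2040 nM

Among the measured compounds shown here, compound 2, at 2040 nM, lies within the scatter of compound 1, the only other measured compound, so the two cannot be ranked. The next compound to be tested is compound 3 `Nc1nc(N)c2cc(CSC(=S)N3CCN(c4ncccn4)CC3)ccc2n1`, which has not yet been measured. It carries pyrimidin-2-yl in place of 4-acetylphenyl on an amine nitrogen in a ring.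

For the measured compounds named here, only one measured step bears on this change, and only indirectly. That step, a 1.0-fold lower number from compound 1 to compound 2 (0.02 log units; within the scatter), brought acetyl in place of methyl on an aromatic carbon and stayed within the scatter. It leaves the aromatic ring itself in place, whereas compound 3 replaces the whole group, so no measurement here tests such a replacement. A small change in this assay is therefore expected, with no firm direction and with wide uncertainty. The expected change is a 1.2-fold higher number from compound 2 to compound 3 (0.09 log units; within the scatter), which would not go beyond the scatter. For compound 3 the estimate is 2500 nM, with an expected range from 800 nM to 8000 nM.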

Compound 3, half-maximal inhibitory concentration: 4360 nM
The estimate for compound 3 lay 1.7-fold (0.24 log units) below the measured number, and the stated range covers the measured number.
By their numbers in this assay, from the lowest: compounds 2 and 1 (each within the scatter of the next); then compound 3.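

In this assay, among the compounds shown here, exchanging the whole aromatic group on the amine nitrogen in the ring is the first change to move the number beyond the scatter, with pyrimidin-2-yl in place of 4-acetylphenyl giving a 2.1-fold higher number from compound 2 to compound 3 (0.33 log units; beyond the scatter) and pyrimidin-2-yl in place of 4-methylphenyl giving a 2.0-fold higher number from compound 1 to compound 3 (0.31 log units; beyond the scatter). Both steps are modest and point the same way, towards weaker inhibition, whereas acetyl in place of methyl on the carbon-only ring, with that ring kept, gave only a 1.0-fold lower number from compound 1 to compound 2 (0.02 log units; within the scatter); at this position, then, replacing the ring registers in this read-out where changing its small group did not. No measurement is available that would account for this shift.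

Pyrimidin-2-yl differs from the two earlier groups both in its ring nitrogen atoms and in carrying no acetyl or methyl group, so the compounds shown do not separate these two differences. Going by these compounds, a plain phenyl or a pyridin-2-yl group on the same nitrogen would bear on that question, and whether a saturated ring such as cyclohexyl is tolerated there also remains open.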